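Fluoro to methyl on a shared core

A few compounds are considered here, and "the series" means these few. Any claim that something is new, unique, unknown or untested is made for them only; others in the source may bear on it.

Measured in a physicochemical assay for lipophilicity, at pH 7.4; a higher number here means a more lipophilic compound, a lower number a more polar compound:
compound 1 `CC(C)(C)c1ccc(C(=O)Nc2cn3cc(-c4ccccc4)ccc3n2)cc1`: 4.83
compound 2 `CNCc1ccc2nc(NC(=O)c3ccc(C(C)(C)C)cc3)cn2c1`: 2.4
compound 3 `CC(C)(C)c1ccc(C(=O)Nc2cn3cc(F)ccc3n2)cc1`: 3.55

Compound 3, at 3.55, stands second highest of the three, above compound 2 and below compound 1. Compound 4 `Cc1ccc2nc(NC(=O)c3ccc(C(C)(C)C)cc3)cn2c1` differs from compound 3 by methyl in place of fluoro on an aromatic carbon, with methyl in place of fluoro on an aromatic carbon. Going by the values given here, two measured steps bear on this site: a number 1.28 log units lower from compound 1 to compound 3 (beyond the scatter) and a number 1.15 log units higher from compound 2 to compound 3 (beyond the scatter). Both are large, but they involve phenyl or (methylamino)methyl, so neither gauges so modest an exchange. The expected change is a small rise, a number 0.25 log units higher from compound 3 to compound 4 (within the scatter), not clearly beyond the scatter. Compound 4 is estimated at 3.8, with an expected range of 3.4 to 4.2.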

Compound 4, distribution coefficient: 3.78
For compound 4 the middle estimate is 0.02 log units above the measured one, within the range that was stated.
By their numbers in this assay, from the lowest: compound 2; then compounds 3 and 4 (each within the scatter of the next); then compound 1.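

In this assay, going by these compounds alone, methyl in place of fluoro gives a number 0.23 log units higher from compound 3 to compound 4 (within the scatter), the first step at this position that stays within the scatter. The large steps here come with the other two groups: hydrogen in place of methylamino on the saturated chain carbon gives a number 1.38 log units higher from compound 2 to compound 4 (beyond the scatter), and methyl in place of phenyl gives a number 1.05 log units lower from compound 1 to compound 4 (beyond the scatter). Among these four compounds, then, only the exchange of fluoro and methyl leaves the number within the scatter. How a carboxylic acid or a longer chain at this position would compare remains open, and nothing shown accounts for the size of any of these steps.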